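A few compounds are considered here, and "the series" means these few. Any claim that something is new, unique, unknown or untested is made for them only; others in the source may bear on it.

Two compounds measured in a functional assay on cells for antagonist activity at C-X-C chemokine receptor type 4 (Homo sapiens), read by fluorescence and calcium flux, with stated times of 25 min and 90 s (on this read-out lower numbers stand for stronger inhibition and higher numbers for weaker inhibition), set the scene. Compound 1 `O=S1(=O)CCC(CNCCCCN(C[C@H]2Cc3ccccc3CN2)[C@H]2CCCc3cccnc32)CC1` gives 17 nM in this assay, and compound 2 `C(=C/CN(C[C@H]1Cc2ccccc2CN1)[C@H]1CCCc2cccnc21)\CNCC1CCOCC1` gives 24.2 nM in this assay; the two numbers lie within the usual scatter of each other, so neither can be called the stronger. Within the data shown here, no single-point step between measured compounds is available. Compound 3 `CC(C)(CCN(C[C@H]1Cc2ccccc2CN1)[C@H]1CCCc2cccnc21)CNCC1CCOCC1` has not yet been measured. Compared with compound 1 it carries a different side group: a group of 12 heavy atoms (10 carbon, 1 nitrogen, 1 oxygen; one six-membered non-aromatic ring with 1 hetero atom) in place of a group of 12 heavy atoms (8 carbon, 1 nitrogen, 2 oxygen, 1 sulfur; one six-membered non-aromatic ring with 1 hetero atom), on a saturated chain carbon, two bonds along the chain from an amine nitrogen. The group that enters matches the corresponding part of compound 2 in its ring, so compound 2 with its value 24.2 nM is the closest guide. The step from compound 1 to compound 3 is expected to be small, a 1.5-fold higher number from compound 1 to compound 3 (0.17 log units; within the scatter), not clearly beyond the scatter in either direction. Compound 3 is therefore expected to give about 25 nM in this assay, with a likely range from 8 nM to 80 nM.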

Compound 3, half-maximal inhibitory concentration: 43.8 nM
For compound 3 the middle estimate is 1.8-fold (0.24 log units) below the measured one; the measured number falls inside the stated range.
By their numbers in this assay, from the lowest: compounds 1, 2 and 3 (each within the scatter of the next, the first and the last beyond it).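

Among these compounds, changing the group on a saturated chain carbon, two bonds along the chain from an amine nitrogen, gives the first step here that can be read in this assay: a 2.6-fold higher number from compound 1 to compound 3 (0.41 log units; beyond the scatter), a modest change that lies beyond the scatter. The position is therefore not indifferent to this exchange, even though the two groups have the same number of heavy atoms and each holds one six-membered non-aromatic ring with 1 hetero atom. No measurement shown here bears on why the number rises.

A single step cannot separate the contribution of the ring from that of the rest of the exchanged group. As far as these compounds go, it also remains open how a piperidine ring or a longer chain would behave at this place.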